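The source may hold more compounds than are shown below. What is called first, only, known or untested is meant among the compounds shown, and "the series" means these compounds.

Measured so far in an assay for inhibition of 15-hydroxyprostaglandin dehydrogenase [NAD(+)] (Homo sapiens), read by fluorescence and spectrophotometry; a higher number here means a weaker inhibitor, a lower number a stronger inhibitor:
compound 1 `Cc1ncsc1CCOc1ccc(/C=C2\SC(=O)NC2=O)cc1Cl`, 5170 nM
compound 2 `O=C1NC(=O)/C(=C/c2ccc(OCCOC3CCCCC3)c(Cl)c2)S1`, 20 nM
compound 3 `O=C1NC(=O)/C(=C/c2ccc(OCC3CCC3)c(Cl)c2)S1`, 9 nM

Compound 3 gives the lowest number of the three, separated from compound 2 by the step of a 2.2-fold lower number from compound 2 to compound 3 (0.35 log units; beyond the scatter) and from compound 1 by the step of a 570-fold lower number from compound 1 to compound 3 (2.76 log units; beyond the scatter). Compound 4 `O=C1NC(=O)/C(=C/c2ccc(OCC3CCCC3)c(Cl)c2)S1` differs from compound 3 by cyclopentyl in place of cyclobutyl on a saturated chain carbon bound to an oxygen on an aromatic ring. Going by the values given here, no measured step exchanges one carbocycle for another at this place: the step of a 2.2-fold lower number from compound 2 to compound 3 (0.35 log units; beyond the scatter) replaces (cyclohexyloxy)methyl with cyclobutyl, and the step of a 260-fold lower number from compound 1 to compound 2 (2.41 log units; beyond the scatter) replaces 4-methyl-1,3-thiazol-5-yl with cyclohexyloxy, both changes far larger than cyclobutyl to cyclopentyl. The nearest guide is the modest gap between compound 2 and compound 3. Compound 4 is therefore expected to lie close to compound 3, with an estimated step of a 1.1-fold lower number from compound 3 to compound 4 (0.05 log units; within the scatter) inside the scatter. The estimated value for compound 4 is 8 nM (range 3 nM to 22 nM).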

Compound 4, half-maximal inhibitory concentration: 11 nM
Compound 4: middle estimate off by 1.4-fold (0.14 log units), on the low side; the measured number falls inside the stated range.
By their numbers in this assay, from the lowest: compounds 3, 4 and 2 (each within the scatter of the next, the first and the last beyond it); then compound 1.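

In this assay, going by these compounds alone, the change from cyclobutyl to cyclopentyl on a saturated chain carbon bound to an oxygen on an aromatic ring gives a 1.2-fold higher number from compound 3 to compound 4 (0.09 log units; within the scatter) and is the first exchange of one carbocycle for another at this place. Cyclopentyl also stands within the scatter of (cyclohexyloxy)methyl through a 1.8-fold lower number from compound 2 to compound 4 (0.26 log units; within the scatter) but remains far from (4-methyl-1,3-thiazol-5-yl)methyl through a 470-fold lower number from compound 1 to compound 4 (2.67 log units; beyond the scatter) as a large step. No supporting data bear on the cause of these results.

As far as these compounds go, whether cyclopropyl or cyclohexyl at this place would stay in the same range remains open. So does the effect of a piperidine ring or a carboxylic acid here.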